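The source may hold more compounds than are shown below. What is called first, only, known or untested is meant among the compounds shown, and "the series" means these compounds.

Measured so far:
compound 1 `CS(=O)(=O)Oc1c(C(=O)NCc2ccc(F)cc2)nc(Br)c2cccnc12`: > 20000 nM
compound 2 `O=C(NCc1ccc(F)cc1)c1nc(Br)c2cccnc2c1NCCO`: > 20000 nM

Both entries come from a functional assay on HCT-116 cells (Homo sapiens) for cytotoxicity, read by MTT assay, with a stated time of 72 h (a higher number here means a weaker inhibitor, a lower number a stronger inhibitor), and both are limits rather than numbers. Compound 2 has no number of its own, only (the limit of > 20000 nM in this assay, at which 2 of the 2 values shown sit). For the measured compounds named here, the single measured step, a step that the two limits leave unreadable from compound 1 to compound 2, gives no size to carry forward.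

Next is compound 3 `Cc1ccc(S(=O)(=O)Oc2c(C(=O)NCc3ccc(F)cc3)nc(Br)c3cccnc23)cc1`, with the change (((4-methylphenyl)sulfonyl)oxy in place of (2-hydroxyethyl)amino on an aromatic carbon). Here ((4-methylphenyl)sulfonyl)oxy takes the place of (2-hydroxyethyl)amino on an aromatic carbon, para to a bromo group. The nearest measured relative is compound 1, which carries (methylsulfonyl)oxy on that carbon. Compound 1 reads > 20000 nM in this assay, again a limit. On that basis, no step beyond the scatter is expected in this assay, and no direction can be argued from the data. The expected step is a number no higher from compound 2 to compound 3 (the limit leaves the size open). For compound 3 the estimated value is 20000 nM, with an expected range from 7000 nM to 40000 nM.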

Compound 3, half-maximal inhibitory concentration: > 20000 nM
Compound 3: a limit, no number; the forecaster's own chance of this, stated with the estimate: 65%; the middle value lies on the limit itself.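

Compound 3 gives no readable step against compound 1 or compound 2, since all three entries in this assay are limits rather than numbers: the limit of > 20000 nM in this assay, at which 3 of the 3 values shown sit.
Whether (methylsulfonyl)oxy, (2-hydroxyethyl)amino and ((4-methylphenyl)sulfonyl)oxy on this aromatic carbon differ at all in this assay remains open, with no number for any compound shown.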